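The source may report more compounds than this note shows. Statements on the series, on what has been measured and on what is new or still open speak of the compounds shown alone.

Going by the values given here, in an ADME assay on the whole organism with Oryza sativa as the target, tested at 1 uM (a higher number here means a weaker effect of the compound at the concentration tested, a lower number a stronger effect), compound 2 `CCOC(=O)c1ccc(NC(=O)N[C@H](C)c2ccccc2)cc1` gives 100%, the higher of the two numbers measured so far, standing above compound 1 `C[C@@H](NC(=O)Nc1ccc(C(F)(F)F)cc1)c1ccccc1`, which gives 89%. Among the compounds with values here, that gap is the one measured step, a number 11 percentage points higher from compound 1 to compound 2 (beyond the scatter), and it concerns the aromatic carbon, not the carbonyl carbon. Compound 3 `CC(=O)c1ccc(NC(=O)N[C@H](C)c2ccccc2)cc1` differs from compound 2 at the carbonyl carbon instead: methyl in place of ethoxy on a carbonyl carbon. Within the data shown here, no measured step bears on this change, so no step beyond the scatter is expected in this assay. The estimate for compound 3 is 95%, within 82% to 100%, a step of a number 5 percentage points lower from compound 2 to compound 3 (within the scatter) that is expected to stay within the scatter.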

Compound 3, a percentage reported as activity, at one concentration (the size of the read-out at that concentration, not a potency): 93%
Compound 3: the middle estimate sits 2 percentage points above what was measured, and the stated range covers the measured number.
By their numbers in this assay, from the lowest: compounds 1, 3 and 2 (each within the scatter of the next, the first and the last beyond it).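

Going by these compounds alone, on the carbonyl carbon, methyl in place of ethoxy gives a number 7 percentage points lower from compound 2 to compound 3 (within the scatter) in this assay, so the loss of ethoxy at this place leaves no step that can be told from the scatter. On the aromatic carbon, acetyl in place of trifluoromethyl gives a number 4 percentage points higher from compound 1 to compound 3 (within the scatter) in this assay, so acetyl, unlike ethoxycarbonyl, is not separated from trifluoromethyl. No available evidence accounts for these numbers. On these data alone, whether an amine or a hydroxy group on the same carbonyl carbon would also stay within the scatter remains open.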